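Nitro to methylcarbamoyl on the benzylamine arm

The source may hold more compounds than are shown below. What is called first, only, known or untested is meant among the compounds shown, and "the series" means these compounds.

Of the compounds shown here, three have been measured in an assay for inhibition of Tryptophan 2,3-dioxygenase (Homo sapiens), with stated times of 10 min and 60 min, tested at 10 uM; a higher number here means a stronger effect of the compound at the concentration tested, a lower number a weaker effect. Compound 1 `Oc1ccc(CNc2cc(C(F)(F)F)cc3[nH]ncc23)cc1` gives 75%. Compound 2 `O=[N+]([O-])c1cccc(CNc2cc(C(F)(F)F)cc3[nH]ncc23)c1` gives 60%, the lowest of the three numbers; compound 1 stands nearest, higher by more than the usual scatter. Compound 3 `O=[N+]([O-])c1ccc(O)cc1CNc1cc(Br)cc2[nH]ncc12` gives 96%, the furthest from compound 2 and again beyond the scatter.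

The next step leads to compound 4 `CNC(=O)c1cccc(CNc2cc(C(F)(F)F)cc3[nH]ncc23)c1`, not yet measured: methylcarbamoyl in place of nitro on an aromatic carbon. Among the compounds with values here, no step between measured compounds that differ in one place exists, so the size cannot be taken from the series. The expectation is a small step upward, not clearly beyond the scatter, a number 5 percentage points higher from compound 2 to compound 4 (within the scatter). Compound 4 is estimated at 65%, with a range from 40% to 85%.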

Compound 4, a percentage reported as inhibition, at one concentration (the size of the read-out at that concentration, not a potency): 71%
For compound 4 the middle estimate is 6 percentage points below the measured one, within the range that was stated.
By their numbers in this assay, from the lowest: compound 2; then compounds 4 and 1 (each within the scatter of the next); then compound 3.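

In this assay, methylcarbamoyl in place of nitro on this aromatic carbon, meta to a large group, gives a number 11 percentage points higher from compound 2 to compound 4 (beyond the scatter). Within the data shown here, this is the first comparison between compounds that differ in one place, and it shows that the read-out at this position responds to the group carried there and is not lost on leaving nitro. No measurement at hand accounts for the step.

On these data alone, whether the gain follows the carbonyl, the amide hydrogen or the methyl stays open; an unsubstituted carboxamide, a carboxylic acid or a nitrile at this carbon would separate these. Also open, as far as these compounds go, is whether the same step holds with bromo in place of trifluoromethyl on the core.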